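A few compounds are considered here, and "the series" means these few. Any claim that something is new, unique, unknown or untested is made for them only; others in the source may bear on it.

Three compounds share one core and differ only in the aromatic group at the far end. Compound 1 `COc1cccc(-c2ccc(COCCCCCN3C[C@H](O)[C@@H](O)[C@H](O)[C@H]3CO)cc2)c1` gives 150 nM in an assay on isolated protein for inhibition of ceramide glucosyltransferase (Homo sapiens); a higher number here means a weaker inhibitor, a lower number a stronger inhibitor. Compound 2 `OC[C@@H]1[C@@H](O)[C@H](O)[C@@H](O)CN1CCCCCOCc1ccc(-c2ccc(C(F)(F)F)cc2)cc1` gives 20 nM, and compound 3 `OC[C@@H]1[C@@H](O)[C@H](O)[C@@H](O)CN1CCCCCOCc1ccc(-c2ccc3c(c2)OCCO3)cc1` gives 40 nM. Among these three numbers compound 3 stands second highest: one gap is a 2.0-fold higher number from compound 2 to compound 3 (0.30 log units; within the scatter), and the other is a 3.8-fold lower number from compound 1 to compound 3 (0.57 log units; beyond the scatter). Compound 4 `OC[C@@H]1[C@@H](O)[C@H](O)[C@@H](O)CN1CCCCCOCc1ccc(-c2ccc(F)nc2)cc1` is not yet measured; it carries 6-fluoropyridin-3-yl in place of 2,3-dihydro-1,4-benzodioxin-6-yl on an aromatic carbon. The two steps that bear on this change are exchanges of the same terminal aromatic group, namely a 7.5-fold lower number from compound 1 to compound 2 (0.88 log units; beyond the scatter) and a 3.8-fold lower number from compound 1 to compound 3 (0.57 log units; beyond the scatter), both modest, while the comparison between compound 2 and compound 3 stayed within the scatter. Since every exchange of this group so far moved the number only modestly, a similarly small effect is expected here, with no clear direction. The estimate for compound 4 is therefore 50 nM, between 18 nM and 150 nM, which is expected to mean a step of a 1.3-fold higher number from compound 3 to compound 4 (0.10 log units; within the scatter).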

Compound 4, half-maximal inhibitory concentration: 750 nM
Estimate against measurement, compound 4: 15-fold (1.18 log units) below, outside the stated range (above it).
By their numbers in this assay, from the lowest: compounds 2 and 3 (each within the scatter of the next); then compound 1; then compound 4.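

This terminal position is less forgiving than the first three compounds suggested: in this assay, the 6-fluoropyridin-3-yl group brings a 19-fold higher number from compound 3 to compound 4 (1.27 log units; beyond the scatter) and a 38-fold higher number from compound 2 to compound 4 (1.57 log units; beyond the scatter), and it even gives a 5.0-fold higher number from compound 1 to compound 4 (0.70 log units; beyond the scatter). So exchanges here need not be small, and compound 4, the only compound shown with a nitrogen in this ring, has the highest number of the four, though one compound cannot separate the nitrogen from the fluorine or from the loss of the second ring present in the 2,3-dihydro-1,4-benzodioxin-6-yl group. Nothing available explains the loss.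

As far as these compounds go, it remains open which of these features matters. A phenyl ring carrying fluorine and a pyridine ring without fluorine would tell them apart, while an amine on the terminal ring would test a different kind of group.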